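Swapping a methyl for 3-chlorophenyl on a piperazine nitrogen

The compounds below may be only part of what the source reports. "The series", "measured", "known", "first", "only" and "open" are said of these compounds alone.

Compound 1 `Cc1ccc(-[n+]2noc([O-])c2CN2CCN(C)CC2)cc1` is assessed in an ADME assay on HEL cells (Homo sapiens) for cytotoxicity (a lower number here means that less compound is tolerated, a higher number that more compound is tolerated), where compound 1 gives 100 ug/mL. Compound 2 `Cc1ccc(-[n+]2noc([O-])c2CN2CCCCC2)cc1` gives 100 ug/mL in this assay, and the step of no change at the digits printed from compound 1 to compound 2 (within the scatter) shows that replacing the ring amine with piperidin-1-yl leaves the tolerated concentration unchanged. Compound 3 `[O-]c1c[n+](-c2ccc(Cc3ccc(-[n+]4cc([O-])on4)cc3)cc2)no1` is reported only as a limit of this assay, >= 20 ug/mL, as noted in the limit of >= 20 ug/mL in this assay, at which 1 of the 3 values shown sits. The unmeasured compound 4 `Cc1ccc(-[n+]2noc([O-])c2CN2CCN(c3cccc(Cl)c3)CC2)cc1` differs from compound 1 by 3-chlorophenyl in place of methyl on an amine nitrogen in a ring. Among the measured compounds shown here, no measured step covers a change of this kind; the only step seen, from compound 1 to compound 2, is flat. Compound 4 is therefore expected to stay close, with the step of a 1.7-fold lower number from compound 1 to compound 4 (0.22 log units; within the scatter) estimated near zero or modestly downward, giving an estimate of 60 ug/mL between 20 ug/mL and 100 ug/mL.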

Compound 4, minimum cytotoxic concentration: 100 ug/mL
Compound 4: the middle estimate sits 1.7-fold (0.22 log units) below what was measured; low and high end bracket the measured number.
By their numbers in this assay, from the lowest: compounds 1, 2 and 4 (each within the scatter of the next).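

In this assay the step reads no change at the digits printed from compound 1 to compound 4 (within the scatter), with 3-chlorophenyl in place of methyl on the amine nitrogen in the ring. Among the compounds shown here, until now the only change seen at this part of the molecule was the swap to piperidin-1-yl; this result shows that the same nitrogen can also carry a six-membered aromatic ring bearing chlorine without a shift in the tolerated concentration.

Going by these compounds, whether a carboxylic acid or a longer chain on this nitrogen would behave the same remains open. Nothing shown explains why the tolerated concentration holds.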